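Ethoxy Cut Back to Methoxy: An Expected Potency Shift

A few compounds are considered here, and "the series" means these few. Any claim that something is new, unique, unknown or untested is made for them only; others in the source may bear on it.

The step from compound 3 to compound 4 is followed here. Compound 3 `CCOc1ccc2cc(C(=O)/C=C/c3c(/C=C/c4ccc(OC)cc4)cc(OC)cc3OC)c(=O)oc2c1` gives 7070 nM in an assay on isolated protein for inhibition of Amine oxidase [flavin-containing] A (Homo sapiens), read by fluorescence, with a stated time of 15 min; a lower number here means a stronger inhibitor, a higher number a weaker inhibitor. Going by the values given here, that is the lowest of the two numbers measured so far; the nearest is compound 2 `COc1ccc(/C=C/c2cc(OC)cc(OC)c2/C=C/C(=O)c2cc3ccc(C)cc3oc2=O)cc1`, which gives 58200 nM in this assay. Compound 1 `COc1ccc(/C=C/c2cc(OC)cc(OC)c2/C=C/C(=O)c2cc3ccc(Cl)cc3oc2=O)cc1` reaches only the limit of the assay, > 60000 nM, in this assay (the limit of > 60000 nM in this assay, at which 1 of the 3 values shown sits). Compound 4 `COc1ccc(/C=C/c2cc(OC)cc(OC)c2/C=C/C(=O)c2cc3ccc(OC)cc3oc2=O)cc1` is not yet measured; it differs from compound 3 as follows: hydrogen in place of methyl on a saturated chain carbon bound to an oxygen on an aromatic ring.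

All three measured steps change the same aromatic position. Ethoxy in place of methyl gave an 8.2-fold lower number from compound 2 to compound 3 (0.92 log units; beyond the scatter), and ethoxy in place of chloro gave an at least 8.4-fold lower number from compound 1 to compound 3 (0.92 log units; beyond the scatter), while methyl in place of chloro gave an at least 1.0-fold lower number from compound 1 to compound 2 (0.01 log units; that floor lies within the scatter). Compound 4 keeps an oxygen on the aromatic ring, as compound 3 does, but the chain reads ethyl to methyl, so its number is expected to lie between those of compound 3 and compound 2, nearer to compound 3. The step anticipated for compound 4 in this assay is a 2.1-fold higher number from compound 3 to compound 4 (0.33 log units; beyond the scatter). For compound 4 the estimate is 15000 nM, with a range from 5000 nM to 45000 nM.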

Compound 4, half-maximal inhibitory concentration: > 60000 nM
Compound 4 gave a limit, no number (the forecaster's own chance of this, stated with the estimate: 10%); middle value at least 4.0-fold (0.60 log units) from the limit.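

Taking ethoxy back to methoxy removes a single methyl, yet it gives an at least 8.4-fold higher number from compound 3 to compound 4 (0.92 log units; beyond the scatter) in this assay, so an oxygen on the aromatic ring is not enough by itself to hold the lower number, and the length of the chain on that oxygen matters in this series. Methoxy in place of methyl on the aromatic carbon gives an at least 1.0-fold higher number from compound 2 to compound 4 (0.01 log units; that floor lies within the scatter), a floor that lies within the scatter, so compound 4 cannot be told apart from compound 2 here, and among the compounds shown only the ethoxy group of compound 3 stands clearly apart. The step from compound 1 to compound 4 cannot be read, because each of the two gives only a limit: the limit of > 60000 nM in this assay, at which 2 of the 4 values shown sit.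

The compounds shown leave open whether the lower number peaks at ethoxy or continues with a longer chain on the oxygen, such as propoxy or butoxy. They also do not tell whether an amine on the same aromatic carbon, carrying an ethyl chain, would behave as ethoxy does.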